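The source may hold more compounds than are shown below. What is called first, only, known or untested is meant among the compounds shown, and "the series" means these compounds.

Compound 2 `ClCc1ccccc1Cn1cnc2c(Cl)ncnc21` and compound 1 `ClCc1ccccc1Cn1cnc2c(Cl)nc(Cl)nc21` differ by chloro in place of hydrogen on an aromatic carbon. In a functional assay on HOP-92 cells (Homo sapiens) for cytotoxicity, read by sulforhodamine B assay, with a stated time of 48 h (a lower number here means a stronger inhibitor of growth, a higher number a weaker inhibitor of growth), compound 2 gives 1480 nM and compound 1 gives 350 nM, a step of a 4.2-fold lower number from compound 2 to compound 1 (0.63 log units; beyond the scatter). Compound 3 `ClCc1cccc(Cn2cnc3c(Cl)ncnc32)c1` has the same atoms as compound 2 joined differently; the difference between the two cores is not broken down here. In this assay compound 3 gives 2450 nM, within the scatter of compound 2, while the gap to compound 1 lies beyond the scatter. Compound 4 `ClCc1cccc(Cn2cnc3c(Cl)nc(Cl)nc32)c1` carries the same kind of change relative to compound 3, (chloro in place of hydrogen on an aromatic carbon), at a place described in the same words as for compound 1. For the measured compounds named here, a step of about the same size, a 3.8-fold lower number from compound 3 to compound 4 (0.58 log units; beyond the scatter), is expected, resting on the one earlier step of a 4.2-fold lower number from compound 2 to compound 1 (0.63 log units; beyond the scatter). Compound 4 is therefore estimated at 650 nM, with a likely range from 250 nM to 1700 nM.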

Compound 4, concentration for 50% growth inhibition: 1820 nM
For compound 4 the middle estimate is 2.8-fold (0.45 log units) below the measured one; measured number above the stated range.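

In this assay, chloro in place of hydrogen on an aromatic carbon gives a 1.3-fold lower number from compound 3 to compound 4 (0.13 log units; within the scatter) and so leaves the two compounds within the scatter of each other. The change therefore does not carry over at one size from one core to the other: the same change on two cores in this assay, a 4.2-fold lower number (0.63 log units; beyond the scatter) from compound 2 to compound 1 and a 1.3-fold lower number (0.13 log units; within the scatter) from compound 3 to compound 4, 3.1-fold (0.50 log units) apart, beyond the scatter of two such steps

A step read on the core of compound 2 cannot be applied unchanged to the core of compound 3 in this series. With a single pair on each core, this shows neither a general rule for the change nor why the two steps differ. Left open is whether an amine or a methoxy group on the same aromatic carbon, between two ring nitrogen atoms, would also give steps that differ between the two cores.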